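A few compounds are considered here, and "the series" means these few. Any claim that something is new, unique, unknown or untested is made for them only; others in the source may bear on it.

Compound 1 `Cc1cc(OCCCCOc2ccc(C(=O)CC(C)C)c(O)c2C)ccc1C(=O)O` in an assay on HEK293 cells for positive allosteric modulation of metabotropic glutamate receptor 3 (Rattus norvegicus), read by thallium flux, with a stated time of 2.5 min (on this read-out lower numbers stand for an effect already at smaller amounts and higher numbers for an effect only at larger amounts of compound), gives 3910 nM. Compound 2 `Cc1c(OCCCCOc2ccc(F)c(C(=O)O)c2)ccc(C(=O)CC(C)C)c1O` in this assay gives 920 nM. For the measured compounds named here, its single difference from compound 1 is 3-carboxy-4-fluorophenyl in place of 4-carboxy-3-methylphenyl on an oxygen on a saturated carbon, and the measured step was a 4.3-fold lower number from compound 1 to compound 2 (0.63 log units; beyond the scatter). Compound 3 `Cc1cc(OCCCCOc2ccc(C(=O)CC3CCCC3)c(O)c2C)ccc1C(=O)O` reached only the limit of this assay, reported as > 10000 nM. Compound 3 differs from compound 1 by cyclopentyl in place of isopropyl on a saturated chain carbon bound to a carbonyl carbon, a step of an at least 2.5-fold higher number from compound 1 to compound 3 (0.40 log units; beyond the scatter). Compound 4 `Cc1c(OCCCCOc2ccc(F)c(C(=O)O)c2)ccc(C(=O)CC2CCCC2)c1O` is not yet measured. Compound 4 differs from compound 3 by 3-carboxy-4-fluorophenyl in place of 4-carboxy-3-methylphenyl on an oxygen on a saturated carbon, the same change, at the same place, as from compound 1 to compound 2; the two cores differ as told by cyclopentyl in place of isopropyl on a saturated chain carbon bound to a carbonyl carbon. For compound 4 the step is expected to be an at least 2.5-fold lower number from compound 3 to compound 4 (0.39 log units; beyond the scatter), resting on the step of a 4.3-fold lower number from compound 1 to compound 2 (0.63 log units; beyond the scatter) seen for this change. The estimate for compound 4 in this assay is 4000 nM, within a range from 1500 nM to 12000 nM.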

Compound 4, half-maximal effective concentration: 2490 nM
Compound 4: middle estimate off by 1.6-fold (0.21 log units), on the high side; low and high end bracket the measured number.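

The change to 3-carboxy-4-fluorophenyl in this assay gives an at least 4.0-fold lower number from compound 3 to compound 4 (0.60 log units; beyond the scatter), so the direction seen on the isopropyl core carries over to the cyclopentyl core: the same change on two cores in this assay, a 4.3-fold lower number (0.63 log units; beyond the scatter) from compound 1 to compound 2 and an at least 4.0-fold lower number (0.60 log units; beyond the scatter) from compound 3 to compound 4; the limit leaves it open whether they differ. Cyclopentyl in place of isopropyl gives a 2.7-fold higher number from compound 2 to compound 4 (0.43 log units; beyond the scatter), again in the direction seen on the other core: the same change on two cores in this assay, an at least 2.5-fold higher number (0.40 log units; beyond the scatter) from compound 1 to compound 3 and a 2.7-fold higher number (0.43 log units; beyond the scatter) from compound 2 to compound 4; the limit leaves it open whether they differ. Compound 3 is recorded only as a limit, > 10000 nM, and the pairs therefore do not show that the steps are equal in size.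

On these data alone, whether the pattern holds on a third core, for example with a phenyl or a longer chain in place of cyclopentyl, stays open. So does the outcome of replacing the carboxylic acid with an amide or a nitrile.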